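The source may report more compounds than this note shows. Statements on the series, on what has been measured and on what is new or still open speak of the compounds shown alone.

In a functional assay, with a stated time of 30 min (on this read-out higher numbers stand for weaker inhibition and lower numbers for stronger inhibition), compound 1 (`CCCCCCCCCCCCOc1cc(OC)c(Br)cc1C(C)=O`) gives 29500000 nM and compound 2 (`CCCCCCCCOc1cc(OC)ccc1C(C)=O`) gives 40000000 nM. These two values lie within the usual scatter of each other, and both are high numbers, which means weak inhibition. Compound 3 (`CCCCCCCCCCCCOc1cc(OC)ccc1C(C)=O`) has not yet been measured. It carries a longer chain than compound 2: butyl in place of hydrogen on a saturated chain carbon, eight bonds along the chain from an oxygen on an aromatic ring. Within the data shown here, no measured step between two closely matched compounds is available as a guide, so no change beyond the scatter is expected. The expected step is a 1.3-fold lower number from compound 2 to compound 3 (0.12 log units; within the scatter). For compound 3 the estimated value is 30000000 nM, with an expected range from 10000000 nM to 90000000 nM.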

Compound 3, half-maximal inhibitory concentration: 37400000 nM
Compound 3: middle estimate off by 1.2-fold (0.10 log units), on the low side, within the range that was stated.
By their numbers in this assay, from the lowest: compounds 1, 3 and 2 (each within the scatter of the next).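

In this assay, butyl in place of hydrogen on a saturated chain carbon gives a 1.1-fold lower number from compound 2 to compound 3 (0.03 log units; within the scatter), so this longer chain does not shift the read-out beyond the scatter. Hydrogen in place of bromo on an aromatic carbon gives a 1.3-fold higher number from compound 1 to compound 3 (0.10 log units; within the scatter), so at this position, too, the swap shows no change beyond the scatter. No evidence is available to explain either result.

Going by these compounds, it remains open whether a chain ending in an amine or a carboxylic acid would change the read-out. The same question stands for a nitrile or a methoxy group in place of bromo on that aromatic carbon.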